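A Phenyl-to-Fluoropyridinyl Swap Beside the Amide

The source may report more compounds than this note shows. Statements on the series, on what has been measured and on what is new or still open speak of the compounds shown alone.

Compound 1 `CCC(NC(=O)C(C)Oc1ccc(Cl)cc1Cl)c1ccc(F)cc1` gives > 100000 nM in an ADME assay on CHO cells (Cricetulus griseus) for cytotoxicity, read by LDH release (on this read-out lower numbers stand for stronger inhibition and higher numbers for weaker inhibition), which is a limit of the assay and not a number.
Compound 2 `CC(Oc1ccc(Cl)cc1Cl)C(=O)Nc1ccc(F)cc1` gives "not determined" (no result reported) in this assay.
Compound 3 `CC(Oc1ccc(Cl)cc1Cl)C(=O)NCc1ccccc1` gives 95000 nM in this assay.

Among the three, compound 3 holds the only actual number; the entry for compound 1 is a limit, and compound 2 carries no result. Going by the values given here, with no two numbers to compare, no step between measured compounds can be sized, and compound 3 simply stands as the one measured point, at the weak end of the scale.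

Compound 4 `CC(Oc1ccc(Cl)cc1Cl)C(=O)NCc1ccc(F)nc1` differs from compound 3 by 6-fluoropyridin-3-yl in place of phenyl on a saturated chain carbon bound to an amide-type nitrogen. The change is small in size and keeps the rest of the molecule intact.

From compound 3 to compound 4 the step is expected to be a 1.1-fold higher number from compound 3 to compound 4 (0.02 log units; within the scatter), meaning no change beyond the usual scatter. Compound 4 is therefore estimated at 100000 nM, within a range from 50000 nM to 200000 nM, and it may well come back only as a limit.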

Compound 4, half-maximal inhibitory concentration: > 100000 nM
Compound 4: only a limit was reported; the forecaster's own chance of this, stated with the estimate: 50%; the middle value lies on the limit itself.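

In this assay, going by these compounds alone, the first comparison at this position, putting 6-fluoropyridin-3-yl in place of phenyl on a saturated chain carbon bound to an amide-type nitrogen gives an at least 1.0-fold higher number from compound 3 to compound 4 (0.02 log units; that floor lies within the scatter). The entry for compound 4 is a limit of the assay and not a number, so this step is only a floor. It still shows that this swap, which brings a hetero atom into the ring and adds a fluorine, does not produce stronger inhibition, and the read-out can show no more than that: the limit of > 100000 nM in this assay, at which 2 of the 4 values shown sit.

Going by these compounds, how much weaker than the limit compound 4 truly is stays open. Also open, on these data alone, is whether an amine or a carboxylic acid on the ring, or a longer chain on the amide-type nitrogen, would bring the read-out down to a clearly lower number.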